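Chlorine on the fused core of two chromone dithiocarbamates

The source may hold more compounds than are shown below. What is called first, only, known or untested is meant among the compounds shown, and "the series" means these compounds.

Measured so far:
compound 1, `O=c1c(SC(=S)N2CCCCC2)coc2ccccc12`: 5800 nM
compound 2, `O=c1cc(CSC(=S)N2CCCCC2)oc2cc(Cl)ccc12`: 1600 nM
compound 3, `O=c1cc(CSC(=S)N2CCCCC2)oc2ccccc12`: 12000 nM

All three numbers come from a functional assay on HEp-2 cells (Homo sapiens) for antiproliferative activity, read by MTT assay, with a stated time of 72 h; a higher number here means a weaker inhibitor, a lower number a stronger inhibitor. Compound 1 stands between the other two: compound 3 gives a higher number than compound 1, and compound 2 a lower one. Compounds 1 and 3 carry the dithiocarbamate on different parts of the shared core; how the two cores differ is not broken down here.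

Within the core of compound 3, one change is documented: chloro in place of hydrogen on an aromatic carbon. It gives a 7.5-fold lower number from compound 3 to compound 2 (0.88 log units; beyond the scatter) in this assay.

Compound 4, `O=c1c(SC(=S)N2CCCCC2)coc2ccc(Cl)cc12`, is not yet measured. It relates to compound 1 as compound 2 relates to compound 3: chloro in place of hydrogen on an aromatic carbon, the same change at the same kind of place. The expectation for compound 4 rests on a single precedent and is therefore held loosely. Among the measured compounds shown here, the step from compound 1 to compound 4 is estimated at a 3.9-fold lower number from compound 1 to compound 4 (0.59 log units; beyond the scatter) in this assay, because a 7.5-fold lower number from compound 3 to compound 2 (0.88 log units; beyond the scatter) is the only guide available. On this basis compound 4 is expected to give about 1500 nM, likely between 600 nM and 5000 nM.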

Compound 4, half-maximal inhibitory concentration: 12200 nM
Compound 4: the middle estimate sits 8.1-fold (0.91 log units) below what was measured; the measured number lies above the stated range.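

In this assay, chloro in place of hydrogen on an aromatic carbon gives a 2.1-fold higher number from compound 1 to compound 4 (0.32 log units; beyond the scatter), so this step does not repeat the one seen on the core of compound 3, and the two steps differ in direction as well as size: the same change on two cores in this assay, a 7.5-fold lower number (0.88 log units; beyond the scatter) from compound 3 to compound 2 and a 2.1-fold higher number (0.32 log units; beyond the scatter) from compound 1 to compound 4, 16-fold (1.20 log units) apart, beyond the scatter of two such steps

In this series, then, the effect of this change on one core cannot be taken as a guide to its effect on the other. Among the compounds shown here, with only one pair on each core, the data do not show whether the difference follows from the core itself, from where the dithiocarbamate is attached, or from where the chloro sits on each core, nor do they show how far it would extend to other compounds.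

The compounds shown leave open whether fluoro or methoxy in place of hydrogen at the same aromatic carbon would also differ between the two cores. They also leave open how an amine at that carbon would behave on either core.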